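The source may report more compounds than this note shows. Statements on the series, on what has been measured and on what is new or still open speak of the compounds shown alone.

Measured compounds and their numbers in a functional assay on MGC-803 cells (Homo sapiens) for inhibition, read by MTT assay, with a stated time of 48 h; on this read-out higher numbers stand for weaker inhibition and lower numbers for stronger inhibition:
- compound 1, `Cc1ccc(NC(=S)NC(=O)c2ccc(OCc3ccccc3Cl)cc2)cc1-c1nc2ccccc2[nH]1`: 45000 nM
- compound 2, `Cc1ccc(NC(=S)NC(=O)c2ccc(OCc3ccc(Cl)cc3Cl)cc2)cc1-c1nc2ccccc2[nH]1`: 3450 nM
- compound 3, `Cc1ccc(NC(=O)NC(=O)c2ccc(OCc3ccccc3)cc2)cc1-c1nc2ccccc2[nH]1`: 39400 nM

Compound 3 stands second highest of these three numbers. Its nearest neighbour is compound 1, whose number lies within the scatter of it, so the two cannot be ordered. Compound 2 gives a number well below both, beyond the scatter.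

Compound 4, `Cc1ccc(NC(=O)NC(=O)c2ccc(OCc3ccccc3Cl)cc2)cc1-c1nc2ccccc2[nH]1`, differs from compound 3 in one place: chloro in place of hydrogen on an aromatic carbon. Going by the values given here, the only measured step that bears on this is a 13-fold lower number from compound 1 to compound 2 (1.12 log units; beyond the scatter), a large drop; there a second chlorine went onto a benzyl ring that already carried one. In compound 4 the first chlorine goes onto a bare benzyl ring, so the two steps are related but not the same. Compound 1, which carries the same 2-chlorobenzyl group as compound 4 but with a thiourea in place of the urea, sits within the scatter of compound 3, which argues against a large gain. A modest step downward is therefore expected, as a 2.0-fold lower number from compound 3 to compound 4 (0.29 log units; within the scatter). Compound 4 is expected to give about 20000 nM in this assay, within a range from 6000 nM to 60000 nM.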

Compound 4, half-maximal inhibitory concentration: 19500 nM
Estimate against measurement, compound 4: 1.0-fold (0.01 log units) above; measured number inside the range.
By their numbers in this assay, from the lowest: compound 2; then compound 4; then compounds 3 and 1 (each within the scatter of the next).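

In this assay, a first chlorine on a bare benzyl ring gives a 2.0-fold lower number from compound 3 to compound 4 (0.31 log units; beyond the scatter), so even a single chlorine at this place, ortho to a large group, has a real though modest effect. Going by these compounds alone, until now, the only step for this change was a second chlorine added to a benzyl ring that already carried one, on a thiourea rather than a urea. The change therefore has no single size across the two cores, and the gain seen earlier cannot be carried over to another compound unaltered: the same change on two cores in this assay, a 13-fold lower number (1.12 log units; beyond the scatter) from compound 1 to compound 2 and a 2.0-fold lower number (0.31 log units; beyond the scatter) from compound 3 to compound 4, 6.5-fold (0.81 log units) apart, beyond the scatter of two such steps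

The compounds shown cannot separate the two differences between these steps, so the larger drop may belong to the second chlorine, to the thiourea, or to the two together. From the compounds shown here alone, how a fluorine, a methoxy group or an amine would compare with chlorine at this place on the ring also remains open.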